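A few compounds are considered here, and "the series" means these few. Any claim that something is new, unique, unknown or untested is made for them only; others in the source may bear on it.

Working notes on the series. Among the compounds with values here, in a functional assay on MCF7 cells (Homo sapiens) for inhibition, read by CCK-8 assay, with a stated time of 48 h (on this read-out higher numbers stand for weaker inhibition and lower numbers for stronger inhibition), compound 1 (`COc1cc(-c2ccnc3cc(-c4ccc(C(F)(F)F)cc4)nn23)cc(OC)c1OC`) gives 2440 nM as the highest of the three numbers so far and is the weakest of the measured compounds. Compound 2 (`COc1cc(-c2ccnc3cc(-c4cn(C)c5ccccc45)nn23)cc(OC)c1OC`) gives 95 nM and compound 3 (`COc1cc(-c2ccnc3cc(-c4ccc5ccn(C)c5c4)nn23)cc(OC)c1OC`) gives 74 nM in the same read-out. Compound 4 (`COc1cc(-c2ccnc3cc(-c4ccc(-c5cnn(C)c5)cc4)nn23)cc(OC)c1OC`) has not yet been measured. Its change from compound 1 is 1-methyl-1H-pyrazol-4-yl in place of trifluoromethyl on an aromatic carbon and amounts to 1-methyl-1H-pyrazol-4-yl in place of trifluoromethyl on an aromatic carbon, para to a large group.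

Within the data shown here, two measured steps bear on this only indirectly. These are a 26-fold lower number from compound 1 to compound 2 (1.41 log units; beyond the scatter) and a 33-fold lower number from compound 1 to compound 3 (1.52 log units; beyond the scatter) and both are large. Each replaces the whole 4-(trifluoromethyl)phenyl, whereas compound 4 keeps the six-membered ring and swaps only the trifluoromethyl, so neither step tests this change directly. The step of a 1.3-fold lower number from compound 2 to compound 3 (0.11 log units; within the scatter) lies within the scatter and gives no reason to favour either indole attachment. Among the measured compounds shown here, the data hold no direct precedent for the new group. The expected change in this assay is an 8.1-fold lower number from compound 1 to compound 4 (0.91 log units; beyond the scatter) as a move in the same direction but smaller than the two large steps. For compound 4 the estimate is 300 nM with an expected range of 80 nM to 1200 nM in this measurement.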

Compound 4, half-maximal inhibitory concentration: 274 nM
Compound 4: middle estimate off by 1.1-fold (0.04 log units), on the high side; the measured number falls inside the stated range.
By their numbers in this assay, from the lowest: compounds 3 and 2 (each within the scatter of the next); then compound 4; then compound 1.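

Keeping the six-membered ring and changing only the group on it, in this assay, gives an 8.9-fold lower number from compound 1 to compound 4 (0.95 log units; beyond the scatter), so the substituent alone moves the number beyond the scatter. The earlier steps shown here replaced the whole 4-(trifluoromethyl)phenyl and could not separate the contribution of this substituent from that of the ring carrying it; this step shows that the aromatic carbon para to a large group is itself a point of change and that it accepts the larger 1-methyl-1H-pyrazol-4-yl with a lower number than trifluoromethyl gives. The change adds a five-membered aromatic ring and hydrogen-bond acceptors at once, and no measurement available here explains the step or assigns it to either feature.

The compounds shown leave open whether the step belongs to the pyrazole ring, to its ring nitrogens or to its methyl group, a question that an unsubstituted 1H-pyrazol-4-yl or a plain phenyl on the same carbon would address. They also leave open how an open-chain dimethylamino group, a morpholine ring or a carboxylic acid would read at this position.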